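Triazole in place of the amine: compound 4

A few compounds are considered here, and "the series" means these few. Any claim that something is new, unique, unknown or untested is made for them only; others in the source may bear on it.

In a functional assay on A549 cells (Homo sapiens) for cytotoxicity, read by MTT assay, with a stated time of 72 h (on this read-out higher numbers stand for weaker inhibition and lower numbers for stronger inhibition), compound 1 `CCN(CC)Cc1ccc(-c2ccnc3ccc(-c4cnc(OC)c(NS(=O)(=O)c5ccc(F)cc5F)c4)cc23)cc1` gives 22 nM, compound 2 `CCN(Cc1ccc(-c2ccnc3ccc(-c4cnc(OC)c(NS(=O)(=O)c5ccc(F)cc5F)c4)cc23)cc1)C1CCCCC1` gives 20.2 nM and compound 3 `COc1ncc(-c2ccc3nccc(-c4ccc(CN5CCN(C(C)C)CC5)cc4)c3c2)cc1NS(=O)(=O)c1ccc(F)cc1F` gives 1.9 nM. Compound 2 thus holds the second highest of the three numbers, its value and that of compound 1 lying within the scatter of each other, while an 11-fold lower number from compound 2 to compound 3 (1.03 log units; beyond the scatter). Compound 4 `COc1ncc(-c2ccc3nccc(-c4ccc(Cn5cncn5)cc4)c3c2)cc1NS(=O)(=O)c1ccc(F)cc1F` differs from compound 2 by 1H-1,2,4-triazol-1-yl in place of cyclohexyl(ethyl)amino on a saturated chain carbon bound to an aromatic carbon. Among the compounds with values here, no measured step covers this change directly; a 1.1-fold lower number from compound 1 to compound 2 (0.04 log units; within the scatter) shows one amine substituent exchanged for another without effect, whereas a 12-fold lower number from compound 1 to compound 3 (1.06 log units; beyond the scatter) shows that a different nitrogen-containing ring at this position can move the number far. The step to compound 4 is therefore expected to be a 2.0-fold higher number from compound 2 to compound 4 (0.30 log units; within the scatter), with the direction uncertain. Compound 4 is estimated at 40 nM in this assay, within 8 nM to 200 nM.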

Compound 4, half-maximal inhibitory concentration: 16 nM
Compound 4: the middle estimate sits 2.5-fold (0.40 log units) above what was measured; measured number inside the range.
By their numbers in this assay, from the lowest: compound 3; then compounds 4, 2 and 1 (each within the scatter of the next).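

Notes on the (1H-1,2,4-triazol-1-yl)methyl change: in this assay, this position accepts a five-membered aromatic ring with 3 hetero atoms in place of either open-chain amine, with a 1.3-fold lower number from compound 2 to compound 4 (0.10 log units; within the scatter) and a 1.4-fold lower number from compound 1 to compound 4 (0.14 log units; within the scatter) both printed as within the scatter. Not every nitrogen-containing ring here matches 4-isopropylpiperazin-1-yl, given an 8.4-fold higher number from compound 3 to compound 4 (0.93 log units; beyond the scatter). No evidence is available to explain these differences. It remains open which part of 4-isopropylpiperazin-1-yl accounts for the low number of compound 3. An unsubstituted piperazin-1-yl, a morpholin-4-yl or an imidazol-1-yl group at this carbon would help to separate the ring from its isopropyl group.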